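This account rests on a few compounds, and the source may have more. Where it says the series, first, only, none or still open, it means among the compounds named here.

In a functional assay on U-251 cells (Homo sapiens) for inhibition, read by MTT assay, with a stated time of 2 days (a lower number here means a stronger inhibitor of growth, a higher number a weaker inhibitor of growth), compound 1 `Nc1ccccc1NC(=O)c1ccc(NCC(=O)Nc2ccc([N+](=O)[O-])cc2)cc1` gives 42500 nM. Compound 2 `COc1ccc(NC(=O)CNc2ccc(C(=O)Nc3ccccc3N)cc2)cc1` gives > 100000 nM, which is a limit of the assay and not a number. Putting methoxy in place of nitro on an aromatic carbon thus gave an at least 2.3-fold higher number from compound 1 to compound 2 (0.37 log units; beyond the scatter). Compound 3 `Nc1ccccc1NC(=O)c1ccc(NCC(=O)Nc2ccc(Cl)cc2)cc1` has chloro in place of methoxy at that same carbon, para to a large group: chloro in place of methoxy on an aromatic carbon. Only the measured step to compound 2, an at least 2.3-fold higher number from compound 1 to compound 2 (0.37 log units; beyond the scatter), bears on this place, so losing the methoxy is expected to bring a modest move to a lower number. The expected step is an at least 2.0-fold lower number from compound 2 to compound 3 (0.30 log units; that floor lies within the scatter). For compound 3 the estimated value is 50000 nM, with an expected range from 20000 nM to 100000 nM.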

Compound 3, concentration for total growth inhibition: 62500 nM
Compound 3: the middle estimate sits 1.3-fold (0.10 log units) below what was measured; measured number inside the range.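

In this assay, chloro and nitro on this aromatic carbon cannot be told apart, with the swap giving a 1.5-fold higher number from compound 1 to compound 3 (0.17 log units; within the scatter). Chloro in place of methoxy gives an at least 1.6-fold lower number from compound 2 to compound 3 (0.20 log units; that floor lies within the scatter), so only a floor is known for this step, and that floor does not separate the two groups. Compound 2 stands at a limit of the assay and not at a number: the limit of > 100000 nM in this assay, at which 1 of the 3 values shown sits.

From the compounds shown here alone, how far methoxy truly lies from chloro and nitro therefore stays open. Also open, going by these compounds, is how an amine or a carboxylic acid on this same carbon would read.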